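The compounds below may be only part of what the source reports. "The series", "measured", "known", "first", "only" and "open" are said of these compounds alone.

Measured so far: compound 1 `COc1cc(-n2cnc3ccc(-c4ccc(C(C)=O)cc4)cc32)cc(OC)c1OC` with 1540 nM in a functional assay on MCF7 cells (Homo sapiens) for antiproliferative activity, read by MTT assay, with a stated time of 72 h (a lower number here means a stronger inhibitor, a higher number a weaker inhibitor), and compound 2 `COc1cc(-n2cnc3ccc(-c4cc(F)ccc4F)cc32)cc(OC)c1OC` with 6420 nM in this assay.

Going by the values given here, compound 1 gives the lowest of these two numbers; the only measured step is a 4.2-fold higher number from compound 1 to compound 2 (0.62 log units; beyond the scatter). Compound 3 `COc1ccc(-c2ccc3ncn(-c4cc(OC)c(OC)c(OC)c4)c3c2)cc1` differs from compound 1 by methoxy in place of acetyl on an aromatic carbon. That measured step replaced the whole 4-acetylphenyl with 2,5-difluorophenyl, a larger change than the one here, so it bears on this step only loosely. A step in this assay that stays within the scatter, or at most a small rise, is expected, namely a 1.6-fold higher number from compound 1 to compound 3 (0.21 log units; within the scatter). Compound 3 is estimated at 2500 nM, with a range from 1000 nM to 6500 nM.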

Compound 3, half-maximal inhibitory concentration: 210 nM
Compound 3: the middle estimate sits 12-fold (1.08 log units) above what was measured, outside the stated range (below it).
By their numbers in this assay, from the lowest: compound 3; then compound 1; then compound 2.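

Methoxy in place of acetyl gives a 7.3-fold lower number from compound 1 to compound 3 (0.87 log units; beyond the scatter) in this assay and so this position, para to a large group, responds clearly to a swap between two small groups that each count one hydrogen-bond acceptor. The 4-methoxyphenyl also compares well with 2,5-difluorophenyl, with a 31-fold lower number from compound 2 to compound 3 (1.49 log units; beyond the scatter) as the widest gap among these compounds. Nothing shown here explains the gain.

From the compounds shown here alone, whether methoxy is special at this position stays open: a hydroxyl, an amine or a longer chain such as ethoxy could show how far the effect extends.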